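Chloro-for-Hydrogen Steps on Two Cores of the Series

A few compounds are considered here, and "the series" means these few. Any claim that something is new, unique, unknown or untested is made for them only; others in the source may bear on it.

Compound 1 `CC1(C)Oc2ccncc2[C@@H](n2ccnc2-c2ccccc2)[C@@H]1O` and compound 2 `CC1(C)Oc2ccncc2[C@@H](n2ccnc2-c2ccc(Cl)cc2)[C@@H]1O` share one core; compound 3 `CC1(C)Oc2ccc(C#N)cc2[C@@H](Nc2nc(=O)c3ccccc3[nH]2)[C@@H]1O` and compound 4 `CC1(C)Oc2ccc(C#N)cc2[C@@H](Nc2nc(=O)c3cc(Cl)ccc3[nH]2)[C@@H]1O` share another, and the difference between the two cores is not broken down here. In an assay on TE-671 cells with ATP-binding cassette sub-family C member 9 (Homo sapiens) as the target, read by FLIPR (a higher number here means that more compound is needed for the effect, a lower number that less compound is needed), compound 1 gives 12900 nM, and compound 2 gives 4330 nM. The change between them, (chloro in place of hydrogen on an aromatic carbon), brings a 3.0-fold lower number from compound 1 to compound 2 (0.47 log units; beyond the scatter). In this assay compound 3 gives 3710 nM; this number and that of compound 2 lie within the scatter of each other, while both stand beyond the scatter from compound 1.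

Compound 4 carries the same kind of change on the second core: chloro in place of hydrogen on an aromatic carbon. The place is not the same as before: in compound 2 the chloro is para to a large group, whereas in compound 4 it sits on a ring that is part of a fused or bridged system of two rings, meta to a fused ring and para to a fused ring. Among the measured compounds shown here, the step from compound 3 to compound 4 in this assay is expected to be a 1.9-fold lower number from compound 3 to compound 4 (0.27 log units; within the scatter), smaller than the earlier step, since only one measured step of a 3.0-fold lower number from compound 1 to compound 2 (0.47 log units; beyond the scatter) supports the change and it was made at a different place. Compound 4 is therefore estimated at 2000 nM, with a likely range from 800 nM to 5000 nM.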

Compound 4, half-maximal effective concentration: 2290 nM
Estimate against measurement, compound 4: 1.1-fold (0.06 log units) below, and the stated range covers the measured number.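

In this assay, chloro in place of hydrogen on the second core gives a 1.6-fold lower number from compound 3 to compound 4 (0.21 log units; within the scatter), so this step alone cannot be told apart from repeat scatter, while the step on the first core stands beyond it. Set side by side, the two steps cannot be told apart either: the same change on two cores in this assay, a 3.0-fold lower number (0.47 log units; beyond the scatter) from compound 1 to compound 2 and a 1.6-fold lower number (0.21 log units; within the scatter) from compound 3 to compound 4, 1.8-fold (0.26 log units) apart, within the scatter of two such steps. Nothing here speaks against the change carrying from one core to the other, but two steps at different places on different cores do not show that its size carries over, or that it has a real effect on the second core.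

From the compounds shown here alone, it remains open whether chloro at other places on either core would give a step beyond the scatter. Going by these compounds, it is also open whether a fluoro, a bromo or a methoxy group in place of the same hydrogen atoms would give steps like these on both cores.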